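A few compounds are considered here, and "the series" means these few. Any claim that something is new, unique, unknown or untested is made for them only; others in the source may bear on it.

Measured so far:
compound 1 `O=S(=O)(NC1=NCCN1C(=S)SN1CCn2c1nsc2=S)c1ccccc1` — >= 20000 nM
compound 2 `O=S(=O)(NC1=NCCN1C(=S)SN1CCn2c1nsc2=S)c1ccc(Cl)c(Cl)c1` — >= 20000 nM

In a functional assay on KYSE-510 cells (Homo sapiens) for antiproliferative activity, read by crystal violet staining, with a stated time of 96 h (a lower number here means a stronger inhibitor of growth, a higher number a weaker inhibitor of growth), compound 1 gives >= 20000 nM, which is a limit of the assay rather than a number. In this assay compound 2 gives >= 20000 nM, likewise a limit. Both values therefore sit at the limit of >= 20000 nM in this assay, at which 2 of the 2 values shown sit. Going by the values given here, the one step between measured compounds, a step that the two limits leave unreadable from compound 1 to compound 2, cannot be read in either direction or size, so compound 2 stands only as a compound with no measured activity below that limit.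

Compound 3 `O=S(=O)(NC1=NCCN1C(=S)SN1CCn2c1nsc2=S)c1ccc2ccccc2c1` is the next variation on the same sulfonyl position: naphthalen-2-yl in place of 3,4-dichlorophenyl on a sulfonyl sulfur. Among the compounds with values here, the only measured step that bears on this place is the unreadable one from compound 1 to compound 2, so no readable change in this assay is expected from compound 2 to compound 3. Compound 3 is estimated at 25000 nM, with a range from 8000 nM to 80000 nM, most likely reported again as a limit. The step this estimate means is expected to be a step that the limit leaves unreadable from compound 2 to compound 3.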

Compound 3, concentration for 50% growth inhibition: >= 20000 nM
Compound 3: only a limit was reported; the forecaster's own chance of this, stated with the estimate: 75%; the middle value lies beyond the limit too.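

No step from compound 1 or compound 2 to compound 3 can be read, as all three values are limits of the assay: the limit of >= 20000 nM in this assay, at which 3 of the 3 values shown sit.

The compounds shown leave open whether any group on the sulfonyl sulfur changes growth inhibition in this assay, and in which direction or by how much.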